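Amide aryl variation on the shared core: thiophene

A few compounds are considered here, and "the series" means these few. Any claim that something is new, unique, unknown or untested is made for them only; others in the source may bear on it.

Measured compounds:
compound 1 `Cc1ccc(C(=O)Nc2cc(-c3ccccc3)nn2-c2ccccc2)cc1` — 30 nM
compound 2 `O=C(Nc1cc(-c2ccccc2)nn1-c1ccccc1)c1ccccn1` — 290 nM
compound 3 `O=C(Nc1cc(-c2ccccc2)nn1-c1ccccc1)c1ccc(Cl)cc1` — 20 nM

The three amides differ only in the group on the carbonyl carbon. In an assay on CHO cells with metabotropic glutamate receptor 5 (Homo sapiens) as the target (a lower number here means that less compound is needed, a higher number that more compound is needed for the effect), compound 1 gives 30 nM and stands second highest of the three numbers; its nearest neighbour is compound 3, and the step of a 1.5-fold lower number from compound 1 to compound 3 (0.18 log units; within the scatter) lies within the scatter, so no order between them can be read. Within the data shown here, the step of a 9.7-fold higher number from compound 1 to compound 2 (0.99 log units; beyond the scatter) is beyond the scatter, as is a 15-fold lower number from compound 2 to compound 3 (1.16 log units; beyond the scatter); both mark pyridin-2-yl as the one group that clearly raises the number.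

Compound 4 `O=C(Nc1cc(-c2ccccc2)nn1-c1ccccc1)c1ccsc1` is the next step from compound 1: thiophen-3-yl in place of 4-methylphenyl on a carbonyl carbon. The step that bears on it is a 9.7-fold higher number from compound 1 to compound 2 (0.99 log units; beyond the scatter), where a ring with a hetero atom also took the place of 4-methylphenyl and the number rose modestly. Compound 3 shows through a 1.5-fold lower number from compound 1 to compound 3 (0.18 log units; within the scatter) that the substituent on a six-membered ring matters little. Among the measured compounds shown here, only one ring with a hetero atom has been measured, so the size of the step is uncertain; a modest rise beyond the scatter is expected, a 2.3-fold higher number from compound 1 to compound 4 (0.37 log units; beyond the scatter). Compound 4 is thus estimated at 70 nM, with a range from 25 nM to 250 nM.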

Compound 4, half-maximal effective concentration: 1800 nM
Compound 4: the middle estimate sits 26-fold (1.41 log units) below what was measured, outside the stated range (above it).
By their numbers in this assay, from the lowest: compounds 3 and 1 (each within the scatter of the next); then compound 2; then compound 4.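

In this assay, a ring with a hetero atom in place of 4-methylphenyl on the carbonyl carbon does not give one fixed step: a 60-fold higher number from compound 1 to compound 4 (1.78 log units; beyond the scatter) is much larger than a 9.7-fold higher number from compound 1 to compound 2 (0.99 log units; beyond the scatter), and a 6.2-fold higher number from compound 2 to compound 4 (0.79 log units; beyond the scatter) separates the two hetero rings beyond the scatter. Thiophen-3-yl is also far from the other ring with a para-free description here, 4-chlorophenyl, as a 90-fold higher number from compound 3 to compound 4 (1.95 log units; beyond the scatter) shows, so this position tolerates the change from methyl to chloro on the six-membered ring but not this change of ring, at least among these four amides. The change replaces a six-membered ring of carbon only with a five-membered ring holding sulfur, drops the ring substituent, and no measurement at hand accounts for the size of the step.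

Open, from the compounds shown here alone, is whether the high number follows the five-membered ring, the sulfur or the loss of the substituent; an unsubstituted phenyl, a furan-3-yl or a cyclopentyl on the carbonyl carbon would bear on that. Also open, going by these compounds, is whether thiophen-2-yl or a methyl-bearing thiophene gives a similar number on the shared core.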